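A few compounds are considered here, and "the series" means these few. Any claim that something is new, unique, unknown or untested is made for them only; others in the source may bear on it.

Measured in a functional assay (mast cells) for inhibition, with Rattus norvegicus as the target; a lower number here means that less compound is needed, a higher number that more compound is needed for the effect:

Compound 1 `COc1ccc(N/N=C2\CCC(C)n3c2ncc(C(=O)O)c3=O)cc1`: 128000 nM
Compound 2 `CCOc1cccc(N/N=C2\CCC(C)n3c2ncc(C(=O)O)c3=O)c1`: 4700 nM

Of these two, compound 2 holds the lower number at 4700 nM, and the gap to compound 1 at 128000 nM lies beyond the scatter. The next compound starts from compound 2. Compound 3 `Cc1cccc(N/N=C2\CCC(C)n3c2ncc(C(=O)O)c3=O)c1` retains the shared core but carries methyl in place of ethoxy on an aromatic carbon, meta to a large group (methyl in place of ethoxy on an aromatic carbon).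

Among the measured compounds shown here, no pair measured so far differs in one place only, so nothing yet shows directly what this exchange does in this assay. For the measured compounds named here, the two values show only that numbers can lie far apart. With compound 2 at 4700 nM, the lower of the two values, a move to a higher number seems more likely than a further fall, and a step beyond the scatter is expected, though not one of great size. The estimate amounts to a 2.6-fold higher number from compound 2 to compound 3 (0.41 log units; beyond the scatter), an expected rise that remains uncertain. For compound 3 the expected value is 12000 nM, with an estimated range from 2500 nM to 60000 nM.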

Compound 3, half-maximal effective concentration: 72900 nM
For compound 3 the middle estimate is 6.1-fold (0.78 log units) below the measured one, and the stated range ends below it.
By their numbers in this assay, from the lowest: compound 2; then compounds 3 and 1 (each within the scatter of the next).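

In this assay, among the compounds shown here, the first direct reading at this position is a 16-fold higher number from compound 2 to compound 3 (1.19 log units; beyond the scatter), a large step for methyl in place of ethoxy on an aromatic carbon, meta to a large group, which shows that this single exchange can move the number by far more than the scatter. The exchange of 3-methylphenyl in place of 4-methoxyphenyl on an amine nitrogen gives a 1.8-fold lower number from compound 1 to compound 3 (0.24 log units; within the scatter), so these two compounds cannot be told apart, and among the three compounds only compound 2, the one carrying ethoxy, stands apart from the others. Nothing available explains why ethoxy and methyl differ so much at this place.

The compounds shown leave open whether the step follows the oxygen or the length of the chain, which methoxy, propoxy or a hydroxy group on the same carbon would help to separate. They also leave open how ethoxy would fare on another carbon of that ring, and whether a longer chain would lower the number further.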